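A Carboxy Group Enters a Series Held at the Limit

The source may hold more compounds than are shown below. What is called first, only, known or untested is meant among the compounds shown, and "the series" means these compounds.

Compound 1 `CC(=O)O[C@H](C/C(C)=C/CO)[C@@]1(C)[C@H](C)CC=C2[C@@H]1CCCC2(C)C` sets the starting point. In a functional assay on U-937 cells (Homo sapiens) for cytotoxicity, read by MTT assay, with a stated time of 72 h (a lower number here means a stronger inhibitor, a higher number a weaker inhibitor), compound 1 reaches only a limit, > 30000 nM. Compound 3 `C/C(=C\CO)C[C@@H](O)[C@@]1(C)[C@H](C)CC=C2[C@@H]1CCCC2(C)C` carries hydrogen in place of acetyl on an oxygen on a saturated carbon; in this assay compound 3 likewise stops at a limit, > 30000 nM. Compound 2 `COc1ccc(C(=O)OC/C=C(\C)C[C@@H](O)[C@@]2(C)[C@H](C)CC=C3[C@@H]2CCCC3(C)C)cc1` bears a (4-methoxyphenyl)carbonyl on that oxygen, and in this assay compound 2 also returns a limit, > 30000 nM. The two steps connecting these structures, a step that the two limits leave unreadable from compound 1 to compound 3 and a step that the two limits leave unreadable from compound 2 to compound 3, therefore cannot be read, because of the limit of > 30000 nM in this assay, at which 3 of the 3 values shown sit. Compound 1 thus stands nowhere distinct among the numbers shown: every value is a limit.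

Compound 4 `CC(=O)O[C@H](C/C(C)=C/C(=O)O)[C@@]1(C)[C@H](C)CC=C2[C@@H]1CCCC2(C)C` differs from compound 1 in one place: carboxy in place of hydroxymethyl on a double-bonded chain carbon bound to a double-bonded chain carbon. Going by the values given here, no measured step touches this position; the measured steps all concern the oxygen on the saturated carbon, and none of them is readable. The account therefore expects no step beyond the scatter in this assay, and the step of a number no higher from compound 1 to compound 4 (the limit leaves the size open) is an estimate resting only on three limits. Compound 4 is estimated at 30000 nM, within 8000 nM to 100000 nM, and is expected most probably to be reported once more as a limit.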

Compound 4, half-maximal inhibitory concentration: > 30000 nM
Compound 4 ended at the assay's limit; the forecaster's own chance of this, stated with the estimate: 75%; the middle value lies on the limit itself.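

The step from compound 1 to compound 4 cannot be read, because compound 1 and compound 4 both stop at a limit in this assay: the limit of > 30000 nM in this assay, at which 4 of the 4 values shown sit. The compounds shown leave open whether carboxy in place of hydroxymethyl, or any change on the oxygen on the saturated carbon, alters the response in this assay at all.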